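Triazole series: pyridin-4-yl for phenyl, Vero cytotoxicity

This account rests on a few compounds, and the source may have more. Where it says the series, first, only, none or still open, it means among the compounds named here.

Compound 2 `Cc1ccccc1Nc1nc(N)nc(CSc2nnc(-c3ccccc3)n2-c2ccccc2)n1` gives 1750 ug/mL in an ADME assay on Vero cells (Chlorocebus sabaeus) for cytotoxicity, read by resazurin assay, with a stated time of 3 days; on this read-out higher numbers stand for lower toxicity in this test and lower numbers for higher toxicity in this test. Compound 1 `Cc1ccccc1Nc1nc(N)nc(CSc2nnc(-c3ccccc3)n2/N=C/c2ccc(Br)cc2)n1` gives 1500 ug/mL in this assay, and the step of a 1.2-fold higher number from compound 1 to compound 2 (0.07 log units; within the scatter) lies within the scatter, so compound 2 and compound 1 cannot be separated on these numbers. Compound 3 `Cc1ccc(Nc2nc(N)nc(CSc3nc4ccccc4[nH]3)n2)cc1` has "not determined" (no result reported) in this assay, so no number is available for it. Compound 4 `Cc1ccccc1Nc1nc(N)nc(CSc2nnc(-c3ccncc3)n2-c2ccccc2)n1` differs from compound 2 by pyridin-4-yl in place of phenyl on an aromatic carbon. For the measured compounds named here, the only measured step, a 1.2-fold higher number from compound 1 to compound 2 (0.07 log units; within the scatter), swapped a group on an aromatic nitrogen; no measured step touches an aromatic carbon of the five-membered ring, so no step beyond the scatter is expected in this assay. Compound 4 is therefore estimated at 1700 ug/mL, within 900 ug/mL to 3200 ug/mL. The expected step is a 1.0-fold lower number from compound 2 to compound 4 (0.01 log units; within the scatter).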

Compound 4, half-maximal cytotoxic concentration: 1650 ug/mL
The estimate for compound 4 lay 1.0-fold (0.01 log units) above the measured number; the measured number falls inside the stated range.
By their numbers in this assay, from the lowest: compounds 1, 4 and 2 (each within the scatter of the next).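

On the aromatic carbon of the five-membered ring, pyridin-4-yl in place of phenyl gives a 1.1-fold lower number from compound 2 to compound 4 (0.03 log units; within the scatter) in this assay. For the compounds shown here, this is the first step read at this position, and like the earlier step on the aromatic nitrogen it stays within the scatter, so the added hydrogen-bond acceptor of pyridin-4-yl leaves no readable mark on this read-out. No measurement shown here bears on the reason for this result.

Only phenyl and pyridin-4-yl stand at this carbon. As far as these compounds go, whether an amine or a carboxylic acid there would also stay within the scatter remains open.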